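The compounds below may be only part of what the source reports. "The series", "measured", "known", "first", "only" and "open" are said of these compounds alone.

Measured compounds:
- compound 1 `COc1cc(OC)c(C(=O)/C=C/c2ccccc2SC)c(OC)c1`: 3%
- compound 2 `COc1cccc(/C=C/C(=O)c2c(OC)cc(OC)cc2OC)c1`: 5.1%
- compound 3 `COc1cc(OC)c(C(=O)/C=C/c2ccc(Cl)cc2)c(OC)c1`: 0%

In a functional assay on NCI-H727 cells (Homo sapiens), read by fluorescence and BrdU incorporation, with a stated time of 48 h, tested at 25 uM (on this read-out lower numbers stand for a stronger effect and higher numbers for a weaker effect at the one concentration tested), compound 1 gives 3%, compound 2 gives 5.1% and compound 3 gives 0%. Compound 2 is separated from compound 1 by a number 2.1 percentage points higher from compound 1 to compound 2 (within the scatter) and from compound 3 by a number 5.1 percentage points lower from compound 2 to compound 3 (within the scatter), both within the scatter, so all three compounds sit at about the same level in this assay.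

Compound 4 `COc1cccc(/C=C/C(=O)c2c(O)cc(OC)cc2OC)c1` differs from compound 2 by hydrogen in place of methyl on an oxygen on an aromatic ring, that is, methoxy to hydroxy on the shared core. For the measured compounds named here, none of the measured steps touches this part: a number 2.1 percentage points higher from compound 1 to compound 2 (within the scatter), a number 3 percentage points lower from compound 1 to compound 3 (within the scatter) and a number 5.1 percentage points lower from compound 2 to compound 3 (within the scatter) all exchange the aryl group on the double-bonded chain carbon, and each stays within the scatter. Going by the values given here, there is therefore no measured step that bears directly on the change to compound 4, and no shift beyond the scatter in this assay is expected. Compound 4 is estimated to give 8%, with a range from 0% to 35%. This corresponds to an expected step of a number 2.9 percentage points higher from compound 2 to compound 4 (within the scatter), within the scatter.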

Compound 4, a percentage reported as activity, at one concentration (the size of the read-out at that concentration, not a potency): 1.4%
Estimate against measurement, compound 4: 6.6 percentage points above, within the range that was stated.
By their numbers in this assay, from the lowest: compounds 3, 4, 1 and 2 (each within the scatter of the next).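

For the compounds shown here, compound 4 is the first compound here in which the shared core changes rather than the aryl group on the double-bonded chain carbon. Swapping methoxy to hydroxy at this position leaves compound 4 level with compound 2 in this assay (a number 3.7 percentage points lower from compound 2 to compound 4 (within the scatter)), so a free hydroxy on the aromatic ring and a capped one cannot be told apart at this single concentration. Nothing measured here offers an explanation for this result.

All four compounds sit at about the same level, so this one concentration leaves open whether they would separate at lower concentrations. From the compounds shown here alone, it also remains unknown how an ethoxy group, a longer chain on the same oxygen, or an amine in place of the hydroxy would read out at this position.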